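The compounds below may be only part of what the source reports. "The series", "measured", "known", "first", "only" and "open" are said of these compounds alone.

Cytotoxicity notes on the series. In an ADME assay on HepG2 cells (Homo sapiens) for cytotoxicity, read by luminescence, CellTiter-Glo and ATP content, with a stated time of 72 h (on this read-out higher numbers stand for an effect only at larger amounts of compound and lower numbers for an effect already at smaller amounts), compound 1 `c1ccc(CCc2ccc3c(NCCCNCc4ccco4)ccnc3c2)cc1` gives 16000 nM, the highest of the two numbers in hand; compound 2 `COc1cccc(CNCCCNc2ccnc3cc(Cc4ccc(F)cc4)ccc23)c1O` gives 4780 nM, a lower number beyond the scatter. Compound 3 `Fc1ccc(Cc2ccc3c(NCCCNCc4ccco4)ccnc3c2)c(Cl)c1` is not yet measured. It differs from compound 1 by 2-chloro-4-fluorophenyl in place of benzyl on a saturated chain carbon bound to an aromatic carbon. Going by the values given here, no measured pair shows this change, so the step is expected to be small: a 1.5-fold lower number from compound 1 to compound 3 (0.16 log units; within the scatter) is the estimate, with direction uncertain and plausibly within the scatter. On that basis compound 3 is expected near 11000 nM, between 4000 nM and 30000 nM.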

Compound 3, half-maximal effective concentration: 5730 nM
Compound 3: the middle estimate sits 1.9-fold (0.28 log units) above what was measured, within the range that was stated.
By their numbers in this assay, from the lowest: compounds 2 and 3 (each within the scatter of the next); then compound 1.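

In this assay, going by these compounds alone, 2-chloro-4-fluorophenyl in place of benzyl on a saturated chain carbon bound to an aromatic carbon gives a 2.8-fold lower number from compound 1 to compound 3 (0.45 log units; beyond the scatter) and is the first step read at this position. The position therefore responds to this change, though the size of the step is modest. No measured property in hand accounts for the step.

The same difference reads as phenethyl to 2-chloro-4-fluorobenzyl, so the shorter chain and the two halogens remain unseparated. As far as these compounds go, how an unsubstituted benzyl or a 2-chlorobenzyl at this place would read stays open.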